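This account rests on a few compounds, and the source may have more. Where it says the series, first, only, none or still open, it means among the compounds named here.

The measured compounds:
compound 1, `C[C@@H](NC(=O)C1(NC(=O)c2cncc(Br)c2)CC1)c1ccc(-n2nc(Cl)c3ccccc32)cc1F`, with 2.5 mL/min/kg;
compound 2, `COc1cc(C(=O)NC2(C(=O)N[C@H](C)c3ccc(-n4nc(Cl)c5ccccc54)cc3F)CC2)on1`, with 5.3 mL/min/kg.

Both numbers come from an in vivo ADME assay on the whole organism (strain Sprague-Dawley) for pharmacokinetics, with Rattus norvegicus as the target; a higher number here means faster removal of the compound, a lower number slower removal. Going by the values given here, compound 2 gives the higher of the two numbers; its only neighbour is compound 1, and the step of a 2.1-fold higher number from compound 1 to compound 2 (0.33 log units; beyond the scatter) separates them. Compound 3, `COc1ncc(C(=O)NC2(C(=O)N[C@H](C)c3ccc(-n4nc(Cl)c5ccccc54)cc3F)CC2)s1`, has not yet been measured. It differs from compound 2 in one place: 2-methoxy-1,3-thiazol-5-yl in place of 3-methoxy-1,2-oxazol-5-yl on a carbonyl carbon. Among the compounds with values here, only one measured step touches the same carbonyl carbon, a 2.1-fold higher number from compound 1 to compound 2 (0.33 log units; beyond the scatter), and that step was modest. Within the data shown here, no measured pair shows an exchange of one five-membered aromatic ring with two hetero atoms for another, so the precedent is indirect at best. On that basis the step of a 1.1-fold higher number from compound 2 to compound 3 (0.05 log units; within the scatter) is expected to be small, if anything a slight rise, and not to reach beyond the scatter. The estimate for compound 3 in this assay is 6 mL/min/kg, with a range from 3 mL/min/kg to 12 mL/min/kg.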

Compound 3, clearance: 12.7 mL/min/kg
For compound 3 the middle estimate is 2.1-fold (0.33 log units) below the measured one, and the stated range ends below it.
By their numbers in this assay, from the lowest: compound 1; then compound 2; then compound 3.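

In this assay the change at the carbonyl carbon from 3-methoxy-1,2-oxazol-5-yl to 2-methoxy-1,3-thiazol-5-yl gives a 2.4-fold higher number from compound 2 to compound 3 (0.38 log units; beyond the scatter) and so shows that two five-membered aromatic rings with matching counts of heavy atoms, hetero atoms and hydrogen-bond acceptors are not interchangeable at this position. Set against 5-bromopyridin-3-yl, the same thiazole gives a 5.1-fold higher number from compound 1 to compound 3 (0.71 log units; beyond the scatter) and this is the widest step among the three compounds, so the position now shows a graded range of clearance, with both five-membered rings above the bromopyridine. Nothing at hand bears on why the two methoxy-substituted rings differ.

The compounds shown cannot separate the part played by the sulfur from the part played by the arrangement of the ring atoms, as the two rings differ in both. As far as these compounds go, how an amine or a plain methyl group in place of the methoxy on the thiazole would move the number in this assay also stays open, as does whether the order of these three compounds would hold for further rings at this carbonyl carbon.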